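From compound 3 to compound 4: working notes

The source may hold more compounds than are shown below. What is called first, only, known or untested is meant among the compounds shown, and "the series" means these compounds.

In a functional assay on HL-60 cells (Homo sapiens) for cytotoxicity, read by WST assay, with a stated time of 48 h (a higher number here means that more compound is needed for the effect, a lower number that less compound is needed), compound 1 (`Cc1ccc(C[C@H]2C(=O)OC[C@@H]2Cc2ccccc2)cc1`) gives 44000 nM and compound 2 (`CCCCOc1ccccc1C[C@H]1COC(=O)[C@@H]1Cc1ccc(Cl)c(Cl)c1`) gives 10000 nM while compound 3 (`Cc1ccccc1C[C@H]1COC(=O)[C@@H]1Cc1ccc(Cl)c(Cl)c1`) gives 22000 nM as its number. Compound 3 lies within the scatter of compound 1 and has a higher number than compound 2. Compound 4 (`O=C1OC[C@H](Cc2ccc(O)cc2)[C@H]1Cc1ccc(Cl)c(Cl)c1`) has 4-hydroxyphenyl in place of 2-methylphenyl on a saturated chain carbon bound to a saturated ring carbon. For the measured compounds named here, the one measured step (a 2.2-fold higher number from compound 2 to compound 3 (0.34 log units; beyond the scatter)) was modest and concerns the same 2-methylphenyl group. Going by the values given here, no measured compound carries 4-hydroxyphenyl, so the guidance is thin. In this assay the estimated step (a 1.5-fold lower number from compound 3 to compound 4 (0.17 log units; within the scatter)) is expected to stay within the scatter. For compound 4 the estimated value is 15000 nM (expected range 5000 nM to 40000 nM).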

Compound 4, half-maximal effective concentration: 37000 nM
Compound 4: the middle estimate sits 2.5-fold (0.39 log units) below what was measured; the range from low to high includes it.
By their numbers in this assay, from the lowest: compound 2; then compounds 3, 4 and 1 (each within the scatter of the next).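

In this assay, a 1.7-fold higher number from compound 3 to compound 4 (0.23 log units; within the scatter) shows that this place on a saturated chain carbon bound to a saturated ring carbon accepts 4-hydroxyphenyl, with its hydrogen-bond donor and acceptor, without a shift beyond the scatter. The step replaces the whole group, so it does not separate the loss of the methyl from the gain of the hydroxyl. Nothing at hand explains the reading. Still open, on these data alone, is how 4-aminophenyl or 4-carboxyphenyl would read at this place, and whether 4-butoxyphenyl would read differently from 4-hydroxyphenyl.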